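Methyl Added to Compound 1: Anticipating Compound 4

The source may report more compounds than this note shows. Statements on the series, on what has been measured and on what is new or still open speak of the compounds shown alone.

In a functional assay on HeLa cells (Homo sapiens) for antiproliferative activity, read by sulforhodamine B assay, with a stated time of 48 h (on this read-out lower numbers stand for stronger inhibition and higher numbers for weaker inhibition), three compounds of a shared core have been measured. Compound 1, `COc1cc(C(=O)/C=C\Nc2ccc(-c3nc4cc(OC)c(OC)c(OC)c4s3)cc2)cc([N+](=O)[O-])c1OC`, gives 7800 nM. Compound 2, `COc1cc(OC)c2sc(-c3ccc(N/C=C\C(=O)c4cc(OC)c(OC)c([N+](=O)[O-])c4)cc3)nc2c1`, gives 19000 nM, and compound 3, `COc1cc(C(=O)/C=C\Nc2ccc(-c3nc4cc(OC)c(OC)c(OC)c4s3)cc2)cc(OC)c1OC`, gives 5300 nM. Compound 1 thus stands second highest of the three numbers; its nearest neighbour is compound 3 and its furthest is compound 2. The step of a 1.5-fold lower number from compound 1 to compound 3 (0.17 log units; within the scatter) remains inside the usual scatter, while the step of a 2.4-fold higher number from compound 1 to compound 2 (0.39 log units; beyond the scatter) is modest but beyond it.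

Compound 4, `COc1cc(C(=O)/C=C\Nc2ccc(-c3nc4cc(OC)c(OC)c(OC)c4s3)cc2C)cc([N+](=O)[O-])c1OC`, differs from compound 1 in a single place: methyl in place of hydrogen on an aromatic carbon. Neither measured step touches this part of the molecule; one removes a methoxy and the other swaps a nitro for a methoxy, both on other rings. The two measured changes of comparable size moved the read-out only modestly or not beyond the scatter, and the methyl is a small, uncharged group with no donors or acceptors. The step of a 1.0-fold higher number from compound 1 to compound 4 (0.01 log units; within the scatter) is therefore expected to fall within the scatter, with no clear direction. Compound 4 is estimated at 8000 nM, with a range from 3500 nM to 18000 nM.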

Compound 4, half-maximal inhibitory concentration: 13100 nM
The estimate for compound 4 lay 1.6-fold (0.21 log units) below the measured number, and the stated range covers the measured number.
By their numbers in this assay, from the lowest: compounds 3, 1, 4 and 2 (each within the scatter of the next, the first and the last beyond it).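

In this assay, among these compounds, the step of a 1.7-fold higher number from compound 1 to compound 4 (0.23 log units; within the scatter) gives the first reading from the ring that the earlier steps left untouched. A methyl on this aromatic carbon, ortho to a large group and meta to a large group, stays within the scatter, so adding this one carbon at this position gives no change that can be told apart from repeat measurement, and the read-out offers no sign that the position is closed to substitution. No measurement at hand bears on what the methyl does at this carbon or on why the number came out as it did.

The compounds shown leave open whether a group other than methyl on this same carbon, such as an ethyl, a methoxy, an amine or a carboxylic acid, would also stay within the scatter or would move the number beyond it. They also leave open whether a methyl on another carbon of this ring would read the same, and whether the same methyl would give a similar step when placed on compound 2 or compound 3.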